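The source may report more compounds than this note shows. Statements on the series, on what has been measured and on what is new or still open speak of the compounds shown alone.

Measured compounds:
compound 1 `CCc1ccc(Nc2cc(NC(=O)Nc3c(Cl)cccc3Cl)ncn2)cc1` gives 31.5% in a functional assay on NCI-H520 cells (Homo sapiens) for inhibition, read by MTT assay, with a stated time of 48 h, tested at 10 uM; on this read-out lower numbers stand for less inhibition and higher numbers for more inhibition at the one concentration tested (going by the name of the read-out)
compound 2 `COc1ccc(OC)c(Nc2cc(NC(=O)Nc3c(Cl)cccc3Cl)ncn2)c1` gives 74% in this assay

Of these two numbers, compound 1 is the lower one, and the gap to compound 2 is beyond the usual scatter. Compound 3 `Cc1ccc(Nc2cc(NC(=O)Nc3c(Cl)cccc3Cl)ncn2)cc1F` has not been measured. It differs from compound 1 by 3-fluoro-4-methylphenyl in place of 4-ethylphenyl on a nitrogen on an aromatic ring. Going by the values given here, no measured pair shows the effect of this change, so the expectation rests on compound 1 alone and is a modest step, a number 4.5 percentage points higher from compound 1 to compound 3 (within the scatter), with no clear direction beyond the scatter. Compound 3 is therefore expected to give about 36%, within 15% to 60%.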

Compound 3, a percentage reported as inhibition, at one concentration (the size of the read-out at that concentration, not a potency): 33.5%
Beside the measured number, compound 3's estimate is 2.5 percentage points above it; the range from low to high includes it.
By their numbers in this assay, from the lowest: compounds 1 and 3 (each within the scatter of the next); then compound 2.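

In this assay there is a number 2 percentage points higher from compound 1 to compound 3 (within the scatter) when 3-fluoro-4-methylphenyl takes the place of 4-ethylphenyl on a nitrogen on an aromatic ring. Going by these compounds alone, this is the first pair here that differs in one place, and it shows that at this position these two groups cannot be told apart by this read-out. No measurement here explains this result.

On these data alone, whether a longer chain such as butyl, an amine or a carboxylic acid on this phenyl ring would move the number beyond the scatter remains open.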